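A few compounds are considered here, and "the series" means these few. Any claim that something is new, unique, unknown or untested is made for them only; others in the source may bear on it.

The measured compounds and their values in this assay:

Compound 1 `O=S(=O)(Nc1ccc(-c2nc3ccccc3o2)cc1)c1cccc(O)c1` shows in an assay on isolated protein for inhibition of malate dehydrogenase, mitochondrial (Sus scrofa), with stated times of 45 min and 30 min (a lower number here means a stronger inhibitor, a higher number a weaker inhibitor), a limit, > 63000 nM.
Compound 2 `O=S(=O)(Nc1ccc2oc(-c3ccccc3)nc2c1)c1ccc(Cl)c(C(F)(F)F)c1` shows in this assay a limit, > 63000 nM.
Compound 3 `CS(=O)(=O)Nc1ccc2oc(-c3ccccc3)nc2c1` shows in this assay a limit, > 63000 nM.

None of these three readings is a number; each is the limit of the assay: the limit of > 63000 nM in this assay, at which 3 of the 3 values shown sit. Compound 1 therefore stands at the limit of this assay, and nothing in the data sets it apart from compound 2 or compound 3. Within the data shown here, no step between two measured compounds is known, so no size of step has been seen in this assay at all.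

Compound 4 `Cc1cccc(S(=O)(=O)Nc2ccc(-c3nc4ccccc4o3)cc2)c1` has not yet been measured. It differs from compound 1 in one place: methyl in place of hydroxy on an aromatic carbon. Because compound 1 shows > 63000 nM in this assay and that reading is a limit, the change cannot be weighed against any measured step here. The step from compound 1 to compound 4 is expected to be small, a step that the limit leaves unreadable from compound 1 to compound 4, none beyond the scatter. Compound 4 is expected to give about 80000 nM in this assay, somewhere from 20000 nM to 300000 nM, and most likely to be reported once more only as a limit.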

Compound 4, half-maximal inhibitory concentration: > 63000 nM
Compound 4 ended at the assay's limit; the forecaster's own chance of this, stated with the estimate: 85%; the middle value is on the limit's open side.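

No step can be read between compound 1 and compound 4, since both readings are limits rather than numbers, and the same holds for all compounds here: the limit of > 63000 nM in this assay, at which 4 of the 4 values shown sit.

The compounds shown leave open what kind of structure, if any, would give an actual number in this assay, and whether methyl and hydroxy differ at all in their effect on this enzyme.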